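From hydroxy to benzyloxy on the shared core

The source may report more compounds than this note shows. Statements on the series, on what has been measured and on what is new or still open speak of the compounds shown alone.

Compound 1 (`Cc1nn(-c2ccccc2)c2nc(O)c(-c3nc(N)cc(N)n3)cc12`): "not determined" (no result reported)
Compound 2 (`Cc1nn(-c2ccccc2)c2nc(OCc3ccccc3F)c(-c3nc(N)c4c(n3)[nH]c(=O)n4C)cc12`): 4900 nM

The series is followed in a functional assay on aorta (Rattus norvegicus, strain Sprague-Dawley) (a higher number here means that more compound is needed for the effect, a lower number that less compound is needed), and offers little to go on so far. In this assay compound 1 reads "not determined" (no result reported) and so has no place on the scale at all. Within the data shown here, compound 2 gives 4900 nM and is the only number available.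

The next compound to be tested is compound 3 (`Cc1nn(-c2ccccc2)c2nc(OCc3ccccc3)c(-c3nc(N)cc(N)n3)cc12`). It comes from compound 1 through a single change, (benzyl in place of hydrogen on an oxygen on an aromatic ring), which puts benzyl in place of hydrogen on an oxygen on an aromatic ring, reading hydroxy to benzyloxy.

Among the measured compounds shown here, no measured step exists from which to size this change, and compound 1 offers no starting number. No size or direction of step can therefore be stated. What is expected instead is that compound 3 returns a plain number of the same order as compound 2 at 4900 nM in this test. For compound 3 the estimate is 3000 nM with 500 nM to 15000 nM as the expected range.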

Compound 3, half-maximal effective concentration: 10800 nM
The estimate for compound 3 lay 3.6-fold (0.56 log units) below the measured number; the range from low to high includes it.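

In this assay compound 1 reads "not determined" (no result reported) and compound 3 gives 10800 nM and no step can be read between the two. On these data alone, what the change from hydroxy to benzyloxy does to the read-out on the shared core stays open. No supporting data bear on the result for compound 3.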